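The source may hold more compounds than are shown below. What is called first, only, known or untested is meant among the compounds shown, and "the series" means these compounds.

Measured compounds: compound 1 `CCc1c(F)c(N)c2c(=O)cc(-c3ccc(N)c(F)c3)oc2c1F` and compound 2 `Nc1ccc(-c2cc(=O)c3c(N)c(F)c(N)c(F)c3o2)cc1F` in a functional assay on HeLa cells (Homo sapiens) for cytotoxicity, read by neutral red uptake, with a stated time of 3 days; on this read-out lower numbers stand for stronger inhibition and higher numbers for weaker inhibition. In this assay compound 1 gives only a limit, > 100000 nM. In this assay compound 2 gives 19000 nM, the only number shown. The other value, that of compound 1, is a limit (the limit of > 100000 nM in this assay, at which 1 of the 2 values shown sits). Compound 3 `CN(C)CCCC(=O)OCc1c(F)c(N)c2c(=O)cc(-c3ccc(N)c(F)c3)oc2c1F` differs from compound 2 by (((3-(dimethylamino)propyl)carbonyl)oxy)methyl in place of amino on an aromatic carbon, on the carbon where the step of an at least 5.2-fold lower number from compound 1 to compound 2 (0.72 log units; beyond the scatter) put the amino in. Going by the values given here, that step, running the other way, is the only guide, so a higher number in this assay is expected for compound 3, of about a 2.6-fold higher number from compound 2 to compound 3 (0.42 log units; beyond the scatter). Compound 3 is estimated at 50000 nM, between 15000 nM and 200000 nM.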

Compound 3, half-maximal inhibitory concentration: 4500 nM
Estimate against measurement, compound 3: 11-fold (1.05 log units) above, and the stated range ends above it.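

In this assay, this aromatic carbon, ortho to two fluoro groups, tolerates far more than a single amino group: (((3-(dimethylamino)propyl)carbonyl)oxy)methyl in place of amino gives a 4.2-fold lower number from compound 2 to compound 3 (0.63 log units; beyond the scatter). Setting ((3-(dimethylamino)propyl)carbonyl)oxy in place of the ethyl methyl gives an at least 22-fold lower number from compound 1 to compound 3 (1.34 log units; beyond the scatter), so a small amino group is not the only change here that lowers the number. Compound 1 gives a limit, not a number: the limit of > 100000 nM in this assay, at which 1 of the 3 values shown sits.

From the compounds shown here alone, what stays open is which part of the new group goes with the lower number. A hydroxymethyl group, or a carboxylic acid in place of the dimethylamino end, would separate the ester from the amine.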